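The compounds below may be only part of what the source reports. "The series", "measured", "known", "first", "only" and "open" are said of these compounds alone.

The study concerns a small set of compounds sharing one core, each tested in a physicochemical assay, with a stated time of 6 min; on this read-out higher numbers stand for weaker inhibition and lower numbers for stronger inhibition. Compound 1 `O=C(Nc1ccc(F)cc1)Nc1nc(-c2cc3cc(Br)ccc3o2)cs1` is known in this assay only as a limit rather than a number, > 200000 nM. Compound 1 stands at the limit of > 200000 nM in this assay, at which 1 of the 3 values shown sits. Compound 2 `COc1cccc(NC(=O)Nc2nc(-c3cc4ccccc4o3)cs2)c1` gives 200 nM in this assay. Compound 3 `O=C(Nc1ccc(I)cc1)Nc1nc(-c2cc3cc([N+](=O)[O-])ccc3o2)cs1` gives 62400 nM in this assay. Compound 4 `O=C(Nc1ccccc1)Nc1nc(-c2cc3cc(Br)ccc3o2)cs1` has not yet been measured; it differs from compound 1 by hydrogen in place of fluoro on an aromatic carbon. Among the measured compounds shown here, no measured pair differs in a single place, so the weight of such a change is unknown from these compounds. Compound 4 is expected to remain a weak inhibitor in this assay, with the step of an at least 2.0-fold lower number from compound 1 to compound 4 (0.30 log units; that floor lies within the scatter) estimated as modest beside a limit. Compound 4 is estimated at 100000 nM, with a range from 20000 nM to 300000 nM.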

Compound 4, half-maximal inhibitory concentration: > 200000 nM
Compound 4: no number, only a limit (the forecaster's own chance of this, stated with the estimate: 50%); at least 2.0-fold (0.30 log units) between middle value and limit.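

Among the compounds shown here, compound 1 and compound 4 are both known only as limits in this assay, so no step between them can be read: the limit of > 200000 nM in this assay, at which 2 of the 4 values shown sit. The compounds shown leave open whether hydrogen in place of fluoro changes inhibition at all.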